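The source may report more compounds than this note shows. Statements on the series, on what has been measured and on what is new or still open speak of the compounds shown alone.

Measured so far in a toxicity assay on NIH3T3 cells (Mus musculus) for cytotoxicity, read by resazurin assay; a higher number here means that more compound is needed for the effect, a lower number that less compound is needed:

Compound 1 `Nc1cc(-c2ccccc2)ccc1Cn1cncc1CNc1ccc(Cl)c(-c2ccccc2)c1` gives > 1000 nM, which is a limit of the assay and not a number.
Compound 2 `COC(=O)c1ccc(NCc2cncn2Cc2ccccc2N)cc1-c1ccccc1` gives 25000 nM.
Compound 3 `O=C(c1ccc(NCc2cncn2Cc2ccc(-c3ccccc3)cc2)cc1-c1ccccc1)N1CCCCC1` gives > 1000 nM, again a limit of the assay and not a number.

Among the measured compounds shown here, compound 2 therefore stands alone as the only compound of the three with an actual number in this assay; the other two sit at the limit of > 1000 nM in this assay, at which 2 of the 3 values shown sit, so they say only that a lot of compound is needed, not how much. For the measured compounds named here, no pair of measured compounds differs in a single place, so no measured step shows what a single change does to this read-out.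

Compound 4 `COC(=O)c1ccc(NCc2cncn2Cc2cccc(F)c2)cc1-c1ccccc1` has not yet been measured. It differs from compound 2 in one place: 3-fluorophenyl in place of 2-aminophenyl on a saturated chain carbon bound to an aromatic nitrogen. A weak hydrogen-bonding aromatic substituent is exchanged for a halogen, and the rest of the molecule, including the shared core of compound 2, is unchanged.

With nothing measured to lean on, the step is expected to be small: a 1.3-fold lower number from compound 2 to compound 4 (0.10 log units; within the scatter), in either direction, not beyond the usual scatter. Compound 4 is accordingly expected to give about 20000 nM in this assay, between 6000 nM and 60000 nM, with a real chance that only a limit is reported.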

Compound 4, half-maximal effective concentration: > 1000 nM
Compound 4: no number, only a limit; the forecaster's own chance of this, stated with the estimate: 40%; the middle value does not contradict the limit.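

In this assay, compound 4 gives > 1000 nM, which is a limit of the assay and not a number. Among the compounds shown here, no step from compound 2 to compound 4 can therefore be read. What remains open is whether 3-fluorophenyl in place of 2-aminophenyl changes the amount of compound needed at all, and most values here give no number: the limit of > 1000 nM in this assay, at which 3 of the 4 values shown sit.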